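Propanoylamino for fluoro on the core of compound 1

The source may report more compounds than this note shows. Statements on the series, on what has been measured and on what is new or still open speak of the compounds shown alone.

The series concerns an ADME assay on MT4 cells (Homo sapiens) for cytotoxicity, read by MTT assay, with a stated time of 96 h; on this read-out higher numbers stand for lower toxicity in this test and lower numbers for higher toxicity in this test. Of the compounds shown here, three have been measured in it. Compound 1, `Fc1ccc(-c2nc3cc(C(F)(F)F)ccc3[nH]2)cc1`, gives 22000 nM in this assay; it is the only compound for which a number, rather than a limit, is shown. Compound 2, `COc1ccc(-c2nc3cc(C(C)=O)ccc3[nH]2)c(OC)c1OC`, gives > 100000 nM in this assay, which is a limit of the assay. Compound 3, `COc1ccc(-c2nc3cc([N+](=O)[O-])ccc3[nH]2)c(OC)c1`, gives > 100000 nM in this assay, likewise a limit. Thus (the limit of > 100000 nM in this assay, at which 2 of the 3 values shown sit), and compound 1 stands as the one point at which a measured number exists.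

Compound 4, `CCC(=O)Nc1ccc(-c2nc3cc(C(F)(F)F)ccc3[nH]2)cc1`, has not yet been measured. It differs from compound 1 in one place: propanoylamino in place of fluoro on an aromatic carbon. Going by the values given here, no step between two measured compounds is available to anchor this change, so the expectation rests on compound 1 alone.

Compound 4 is expected to sit at 40000 nM, within a range of 15000 nM to 120000 nM. This corresponds to an expected step of a 1.8-fold higher number from compound 1 to compound 4 (0.26 log units; within the scatter), a modest move toward lower toxicity in this assay that may not clearly exceed the usual scatter.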

Compound 4, half-maximal cytotoxic concentration: >= 100000 nM
Compound 4: only a limit was reported; the forecaster's own chance of this, stated with the estimate: 30%; middle value at least 2.5-fold (0.39 log units) away from the limit.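

In this assay, going by these compounds alone, propanoylamino in place of fluoro on an aromatic carbon, para to a large group, gives an at least 4.5-fold higher number from compound 1 to compound 4 (0.65 log units; beyond the scatter), the first step that can be read between two compounds differing in one place. The step lies beyond the scatter, so at this position the change moves the read-out toward lower toxicity in this test. Compound 4 is reported only as a limit of the assay, so the step gives a minimum size and not a full size: the limit of >= 100000 nM in this assay, at which 1 of the 4 values shown sits.

From the compounds shown here alone, how far compound 4 lies past its limit stays open, and so does the full size of the step. Also open, going by these compounds, is whether an amine, a carboxylic acid or a longer acyl chain at this position would give a similar read-out on the core of compound 1.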